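Hydrazone aryl swap: from compound 2 to compound 3

This account rests on a few compounds, and the source may have more. Where it says the series, first, only, none or still open, it means among the compounds named here.

Two members of the series carry numbers in a functional assay on MGC-803 cells (Homo sapiens) for antiproliferative activity, read by MTT assay, with a stated time of 72 h; a lower number here means a stronger inhibitor, a higher number a weaker inhibitor. Compound 1 `CCCSc1nc(N/N=C(\C)c2ccccc2O)c2nnn(Cc3ccccc3Cl)c2n1` gives 35000 nM there. Compound 2 `CCCSc1nc(N/N=C/c2ccc(N(C)C)cc2)c2nnn(Cc3ccccc3)c2n1` gives 13100 nM, the lower of the two numbers shown, and its gap to compound 1 lies beyond the usual scatter of this assay. Compound 3 `CCCSc1nc(N/N=C/c2c[nH]c3ccccc23)c2nnn(Cc3ccccc3)c2n1` has not yet been measured. It differs from compound 2 in one place: 1H-indol-3-yl in place of 4-(dimethylamino)phenyl on a carbon with a double bond to nitrogen. Among the compounds with values here, no pair of measured compounds differing in a single place exists, so this change has no measured precedent here and the expectation rests on the two values alone. In this assay the step expected for the change is a 1.5-fold lower number from compound 2 to compound 3 (0.16 log units; within the scatter), a modest move toward a lower number, not far outside the scatter. Compound 3 is expected to give about 9000 nM, within a range of 3000 nM to 30000 nM.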

Compound 3, half-maximal inhibitory concentration: 7410 nM
The estimate for compound 3 lay 1.2-fold (0.08 log units) above the measured number; measured number inside the range.
By their numbers in this assay, from the lowest: compounds 3 and 2 (each within the scatter of the next); then compound 1.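

Within the data shown here, the only single-place comparison falls on the carbon with a double bond to nitrogen: in this assay, the aryl swap gives a 1.8-fold lower number from compound 2 to compound 3 (0.25 log units; within the scatter). At this position, a single six-membered carbon ring with a dimethylamino group and an indole with a hydrogen-bond donor, both of 9 heavy atoms, therefore cannot be told apart in this assay. Nothing available accounts for the size of this step.

From the compounds shown here alone, whether the indole hydrogen matters remains open, and 1-methyl-1H-indol-3-yl or an unsubstituted phenyl at the same carbon would address that question. The separate contributions of the 2-chlorobenzyl group and the added methyl in compound 1 also remain unresolved, as does the effect of a longer chain on the sulfur.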